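Methoxy in Place of Chloro: Expected Cytotoxicity Shift

The source may hold more compounds than are shown below. What is called first, only, known or untested is meant among the compounds shown, and "the series" means these compounds.

Of the compounds shown here, three have been tested in an ADME assay on HEK-293T cells (Homo sapiens) for cytotoxicity, read by CCK-8 assay, with a stated time of 48 h; a lower number here means that less compound is tolerated, a higher number that more compound is tolerated. Compound 1, `COc1cccc2c(SCC(=O)Nc3ccc(Cl)c(Cl)c3)c[nH]c12`, gives > 100000 nM, which is a limit of the assay rather than a number. Compound 2, `Cn1cc(S(=O)(=O)CC(=O)Nc2cccc(Cl)c2Cl)c2ccccc21`, gives > 100000 nM, again a limit. Going by the values given here, compound 3, `CCOc1ccccc1NC(=O)CSc1c[nH]c2cccc(Cl)c12`, is the only one to return a number, 25200 nM, so it stands alone against (the limit of > 100000 nM in this assay, at which 2 of the 3 values shown sit). Compound 4, `CCOc1ccccc1NC(=O)CSc1c[nH]c2cccc(OC)c12`, is not yet measured; it differs from compound 3 by methoxy in place of chloro on an aromatic carbon. Among the compounds with values here, no step between measured compounds follows this change, so no measured direction is available. Compound 1 carries a methoxy and gives > 100000 nM, a limit. On that ground compound 4 is expected to move toward less cytotoxicity, by a step of a 2.4-fold higher number from compound 3 to compound 4 (0.38 log units; beyond the scatter) beyond the scatter. Compound 4 is estimated at 60000 nM, within 20000 nM to 120000 nM, with a fair chance of only a limit.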

Compound 4, half-maximal cytotoxic concentration: > 100000 nM
Compound 4: only a limit was reported (the forecaster's own chance of this, stated with the estimate: 55%); at least 1.6-fold (0.22 log units) between middle value and limit.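

On the shared core, methoxy in place of chloro on an aromatic carbon gives an at least 3.9-fold higher number from compound 3 to compound 4 (0.59 log units; beyond the scatter) in this assay, the only measured step at this position among the compounds shown. Within this pair, the chloro compound alone returns a number, and the step gives a lower bound rather than a full size. Compound 4 now also sits at the limit: the limit of > 100000 nM in this assay, at which 3 of the 4 values shown sit.

From the compounds shown here alone, whether fluoro, an amine or a longer alkoxy chain at this position would give a number or reach the limit remains open. Going by these compounds, the size of the change beyond the limit also remains open.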